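The source may report more compounds than this note shows. Statements on the series, on what has been measured and on what is new or still open speak of the compounds shown alone.

Working notes on the series. The shared core of compound 2, `Cc1ccc(/C=C2\CN(Cc3cn(Cc4cccc(Cl)c4)nn3)C/C(=C\c3ccc(C)cc3)C2=O)cc1`, carries a benzyl group on the triazole nitrogen, and the series varies that benzyl along with the two arylidene groups on the core. Compound 1, `COc1ccc(/C=C2\CN(C(=S)SCc3cn(Cc4ccccc4Cl)nn3)C/C(=C\c3ccc(OC)cc3)C2=O)cc1`, gives a limit rather than a number in a functional assay on MCF7 cells (Homo sapiens) for cytotoxicity, read by MTT assay, with a stated time of 24 h; on this read-out higher numbers stand for weaker inhibition and lower numbers for stronger inhibition: compound 1 reads > 100000 nM, which is a limit of the assay (the limit of > 100000 nM in this assay, at which 1 of the 3 values shown sits). Compound 3, `O=C1/C(=C/c2ccccc2F)CN(Cc2cn(Cc3ccccc3F)nn2)C/C1=C\c1ccccc1F`, gives 6000 nM in this assay. Compound 2 gives 10000 nM in this assay; of the two numbers shown it is the higher, but compound 2 and compound 3 sit within the scatter of each other, so no order between them is claimed.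

Compound 4, `Cc1ccc(/C=C2\CN(Cc3cn(Cc4ccc(F)cc4)nn3)C/C(=C\c3ccc(C)cc3)C2=O)cc1`, differs from compound 2 at one place: 4-fluorophenyl in place of 3-chlorophenyl on a saturated chain carbon bound to an aromatic nitrogen. No measured step of this kind exists among the compounds shown, so nothing indicates a shift beyond the scatter in either direction; the expected step from compound 2 to compound 4 in this assay is no change at the digits printed from compound 2 to compound 4 (within the scatter). Compound 4 is therefore estimated at 10000 nM in this assay, with a range from 4000 nM to 25000 nM.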

Compound 4, half-maximal inhibitory concentration: 29000 nM
Beside the measured number, compound 4's estimate is 2.9-fold (0.46 log units) below it; the measured number lies above the stated range.
By their numbers in this assay, from the lowest: compounds 3 and 2 (each within the scatter of the next); then compound 4. At a limit, above all of these: compound 1.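

Among the compounds shown here, the place on a saturated chain carbon bound to an aromatic nitrogen responds to substitution in this assay: 4-fluorophenyl in place of 3-chlorophenyl gives a 2.9-fold higher number from compound 2 to compound 4 (0.46 log units; beyond the scatter) and this is the first step that can be read at one place. It rests on a single pair with the two arylidene groups held the same, so it shows that this place matters and gives no rule for other groups there. No measurement shown bears on the reason for this step.

Open, from the compounds shown here alone, is whether the step follows the change of halogen or the change of its place on the ring, which 4-chlorophenyl or 3-fluorophenyl would separate. Open too, going by these compounds, is whether it holds with other arylidene groups on the shared core, and what an unsubstituted phenyl or a pyridyl group would do at this place.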